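The source may report more compounds than this note shows. Statements on the series, on what has been measured and on what is new or still open speak of the compounds shown alone.

Measured so far:
compound 1, `CCCS(=O)(=O)Nc1ccc(F)c(C(=O)c2n[nH]c3ncc(-c4ccccc4Cl)cc23)c1F`, gives 9.3% in an assay for binding affinity to dual specificity mitogen-activated protein kinase kinase 4 (Homo sapiens), read by KINOMEscan, tested at 100 nM; a higher number here means a weaker effect of the compound at the concentration tested, a lower number a stronger effect
compound 2, `CCCS(=O)(=O)Nc1ccc(F)c(C(=O)c2n[nH]c3ncc(-c4cccc([N+](=O)[O-])c4)cc23)c1F`, gives 15% in this assay

Going by the values given here, compound 2 holds the higher of the two numbers in this assay, but the single step between them, a number 5.7 percentage points higher from compound 1 to compound 2 (within the scatter), does not separate them. Compound 3, `CCCS(=O)(=O)Nc1ccc(F)c(C(=O)c2n[nH]c3ncc(-c4ccc([N+](=O)[O-])cc4)cc23)c1F`, differs from compound 2 by 4-nitrophenyl in place of 3-nitrophenyl on an aromatic carbon. Among the compounds with values here, no measured step moves the nitro group within the phenyl ring; the one step available changes a different substituent and stays within the scatter, so for compound 3 no movement beyond the scatter is expected: no change at the digits printed from compound 2 to compound 3 (within the scatter). Compound 3 is estimated at 15%, with a range from 4% to 35%.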

Compound 3, a percentage reported as activity, at one concentration (the size of the read-out at that concentration, not a potency): 4.2%
Compound 3: the middle estimate sits 10.8 percentage points above what was measured, and the stated range covers the measured number.
By their numbers in this assay, from the lowest: compounds 3, 1 and 2 (each within the scatter of the next, the first and the last beyond it).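

Within this assay, the place of the nitro group on the phenyl ring matters: a number 10.8 percentage points lower from compound 2 to compound 3 (beyond the scatter) is the first step in the series beyond the scatter, with the same atoms joined differently. Against 2-chlorophenyl, the picture differs: a number 5.1 percentage points lower from compound 1 to compound 3 (within the scatter) does not separate 4-nitrophenyl from that group. Nothing available explains the difference between the two nitrophenyl groups.

As far as these compounds go, whether an amine or a carboxylic acid in place of the nitro group on 4-nitrophenyl would keep the number of compound 3 4.2% remains open.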